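Carboxymethyl on the Ring Nitrogen: Expected Cytotoxicity

A few compounds are considered here, and "the series" means these few. Any claim that something is new, unique, unknown or untested is made for them only; others in the source may bear on it.

Measured compounds:
compound 1, `O=C1NC(=S)S/C1=C\c1cc2cc(Cl)ccc2nc1Cl`, gives > 100 ug/mL.
compound 2, `O=C1NC(=S)S/C1=C\c1cc2cc(F)ccc2nc1Cl`, gives > 100 ug/mL.

In a toxicity assay on A549 cells (Homo sapiens) for cytotoxicity, read by MTT assay, with a stated time of 48 h (a higher number here means a weaker inhibitor of growth, a lower number a stronger inhibitor of growth), compound 1 gives > 100 ug/mL, which is a limit of the assay and not a number. Compound 2 gives > 100 ug/mL, again a limit and not a number. Because the limit of > 100 ug/mL in this assay, at which 2 of the 2 values shown sit, holds for both, the step that the two limits leave unreadable from compound 1 to compound 2 cannot be read in either size or direction. Compound 3, `O=C(O)CN1C(=O)/C(=C/c2cc3cc(F)ccc3nc2Cl)SC1=S`, differs from compound 2 by carboxymethyl in place of hydrogen on an amide-type nitrogen in a ring. Among the measured compounds shown here, no measured step bears on this change, and the only step known, fluoro for chloro, is itself unreadable. Compound 2 therefore stands at the limit, with no scale of step sizes around it. The step that the limit leaves unreadable from compound 2 to compound 3 is expected to stay within the scatter, since no evidence points either way. Compound 3 is estimated at 150 ug/mL, between 50 ug/mL and 400 ug/mL.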

Compound 3, concentration for 50% growth inhibition: > 100 ug/mL
Compound 3 was reported as a limit (the forecaster's own chance of this, stated with the estimate: 75%); the middle value is on the limit's open side.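

Compound 3 gives > 100 ug/mL which is a limit and not a number. The step from compound 2 to compound 3 therefore cannot be read in size or direction, since both sit at one limit: the limit of > 100 ug/mL in this assay, at which 3 of the 3 values shown sit. In this assay the compounds shown leave open whether carboxymethyl in place of hydrogen, or fluoro in place of chloro, changes growth inhibition at all.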